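From dimethylphenyl to chloromethylphenyl among assay limits

The compounds below may be only part of what the source reports. "The series", "measured", "known", "first", "only" and "open" are said of these compounds alone.

Values measured in a functional assay on HepG2 cells (Homo sapiens) for antiproliferative activity, read by spectrophotometry, with a stated time of 2 days (on this read-out lower numbers stand for stronger inhibition of growth and higher numbers for weaker inhibition of growth), follow as a short list.
- Compound 1 `Cc1ccc(Nc2ncc(C(F)(F)F)c(N3Cc4cccc(N(C)S(C)(=O)=O)c4C3)n2)cc1C` gives > 30000 nM as a limit
- Compound 2 `Cc1ccc(Nc2ncc(C(F)(F)F)c(N3Cc4cccc(N(C)S(C)(=O)=O)c4C3)n2)c(Cl)c1` gives > 30000 nM as a limit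
- Compound 3 `CN(c1cccc2c1CN(c1nc(Nc3ccc(Nc4ccccc4)cc3)ncc1C(F)(F)F)C2)S(C)(=O)=O` gives 8600 nM as a number

For compound 1 there is only a limit (the limit of > 30000 nM in this assay, at which 2 of the 3 values shown sit) and no number. Compound 4 `Cc1cc(Cl)ccc1Nc1ncc(C(F)(F)F)c(N2Cc3cccc(N(C)S(C)(=O)=O)c3C2)n1` carries one change (4-chloro-2-methylphenyl in place of 3,4-dimethylphenyl on a nitrogen on an aromatic ring) on the shared core: 4-chloro-2-methylphenyl in place of 3,4-dimethylphenyl on a nitrogen on an aromatic ring. The closest measured swap there is a step that the two limits leave unreadable from compound 1 to compound 2 and so offers no size to carry over. Because compound 2 gives > 30000 nM as a limit, compound 4 is expected to remain weak, with no step beyond the scatter. In this assay the expected step (a number no higher from compound 1 to compound 4 (the limit leaves the size open)) has no firm direction. For compound 4 the estimate is 30000 nM (expected range 12000 nM to 60000 nM) and probably only a limit will be reported.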

Compound 4, concentration for 50% growth inhibition: 19600 nM
Compound 4: the middle estimate sits 1.5-fold (0.18 log units) above what was measured; low and high end bracket the measured number.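

In this assay the 4-chloro-2-methylphenyl group on this nitrogen is the only one of the three methyl-bearing phenyl groups shown to give a number rather than a limit. The change reads as an at least 1.5-fold lower number from compound 1 to compound 4 (0.18 log units; that floor lies within the scatter) and as an at least 1.5-fold lower number from compound 2 to compound 4 (0.18 log units; that floor lies within the scatter) in the second pair, so a real gain is not established. The step between compound 1 and compound 2 cannot be read, since both stop at a limit: the limit of > 30000 nM in this assay, at which 2 of the 4 values shown sit.

As far as these compounds go, how far compound 1 and compound 2 truly lie from compound 4 stays open. So does whether an amine or a carboxylic acid in place of the chlorine on that phenyl ring would carry the number beyond the scatter.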